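Cyclohexyl to 4-nitrophenyl on the shared core

This account rests on a few compounds, and the source may have more. Where it says the series, first, only, none or still open, it means among the compounds named here.

Values in a functional assay on MCF7 cells (Homo sapiens) for inhibition, read by MTT assay, with a stated time of 48 h; a higher number here means a weaker inhibitor, a lower number a stronger inhibitor:
- compound 1 `COc1cccc(C(c2c[nH]c3ccc(Br)cc23)c2c[nH]c3ccc(Br)cc23)c1OC`: 89000 nM
- compound 2 `COc1ccc(C(c2c[nH]c3ccc(Br)cc23)c2c[nH]c3ccc(Br)cc23)c(OC)c1`: 77500 nM
- compound 3 `Brc1ccc2[nH]cc(C(c3c[nH]c4ccc(Br)cc34)C3CCCCC3)c2c1`: 4100 nM

Compound 3 has the lowest number of the three, and its steps to both others lie beyond the scatter. Compound 4 `O=[N+]([O-])c1ccc(C(c2c[nH]c3ccc(Br)cc23)c2c[nH]c3ccc(Br)cc23)cc1`, not yet measured, carries 4-nitrophenyl in place of cyclohexyl on a saturated chain carbon bound to two aromatic carbons.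

Within the data shown here, two measured steps bear on this change, both large and both ending in cyclohexyl: a 22-fold lower number from compound 1 to compound 3 (1.34 log units; beyond the scatter) and a 19-fold lower number from compound 2 to compound 3 (1.28 log units; beyond the scatter). The step of a 1.1-fold lower number from compound 1 to compound 2 (0.06 log units; within the scatter) shows no separation between the two dimethoxyphenyl compounds. Among the measured compounds shown here, no 4-nitrophenyl compound has been measured, so carrying these steps over in reverse is uncertain, and the full size is not assumed. A sizeable rise is expected in this assay, with an estimated 9.8-fold higher number from compound 3 to compound 4 (0.99 log units; beyond the scatter). For compound 4 the estimate is 40000 nM, with an expected range of 12000 nM to 100000 nM.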

Compound 4, half-maximal inhibitory concentration: 3100 nM
Compound 4: middle estimate off by 13-fold (1.11 log units), on the high side; the measured number lies below the stated range.
By their numbers in this assay, from the lowest: compounds 4 and 3 (each within the scatter of the next); then compounds 2 and 1 (each within the scatter of the next).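

In (this assay), an aromatic ring on this carbon does not by itself go with the high numbers: 4-nitrophenyl and cyclohexyl stand level (a 1.3-fold lower number from compound 3 to compound 4 (0.12 log units; within the scatter)). The large separation therefore also appears among aromatic groups, with 4-nitrophenyl in place of either dimethoxyphenyl (a 25-fold lower number from compound 2 to compound 4 (1.40 log units; beyond the scatter)) and (a 29-fold lower number from compound 1 to compound 4 (1.46 log units; beyond the scatter)), so in these four compounds the high numbers stay with compound 1 and compound 2 and do not follow the change from cyclohexyl to an aromatic ring. No measurement on these compounds addresses what lies behind this.

Still open, from the compounds shown here alone, is whether the large steps come with both methoxy groups together or with one alone, which a plain phenyl or a monomethoxyphenyl group on this carbon would help to separate. Going by these compounds, whether an open chain such as hexyl stands level with cyclohexyl also remains unknown.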